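Methoxy Additions on Styryl Sulfones Against Breast Cancer Cells

The compounds below may be only part of what the source reports. "The series", "measured", "known", "first", "only" and "open" are said of these compounds alone.

Compound 1, `COc1ccc(/C=C/S(=O)(=O)Cc2ccc(OC)cc2)cc1`, gives > 20000 nM in a functional assay on BT-20 cells (Homo sapiens) for antiproliferative activity, read by trypan blue exclusion (a higher number here means a weaker inhibitor, a lower number a stronger inhibitor), a limit of the assay. Compound 2, `COc1ccc(CS(=O)(=O)/C=C/c2ccccc2OC)cc1`, gives 5000 nM in this assay. Compound 3, `COc1ccc(CS(=O)(=O)/C=C/c2ccc(OC)c(OC)c2)cc1`, gives > 20000 nM, again a limit.

Compound 1 and compound 2 hold the same atoms joined differently; the difference between the two cores is not broken down here. Going by the values given here, compound 2 carries the only number among the three. The change from compound 1 to compound 3 is methoxy in place of hydrogen on an aromatic carbon, and its step, a step that the two limits leave unreadable from compound 1 to compound 3, has no readable size because both ends sit at the limit of > 20000 nM in this assay, at which 2 of the 3 values shown sit.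

Compound 4, `COc1ccc(CS(=O)(=O)/C=C/c2cc(OC)ccc2OC)cc1`, is not yet measured. It differs from compound 2 by methoxy in place of hydrogen on an aromatic carbon, the same kind of change as that from compound 1 to compound 3, though the place differs: there the entering methoxy stood ortho to a methoxy group and meta to a large group, here it stands meta to a large group and para to a methoxy group. The expected step is a 1.6-fold higher number from compound 2 to compound 4 (0.20 log units; within the scatter), which rests on compound 2 giving 5000 nM and on the earlier step being unreadable. Compound 4 is estimated at 8000 nM, between 2500 nM and 25000 nM.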

Compound 4, half-maximal inhibitory concentration: > 20000 nM
Compound 4 ended at the assay's limit; the forecaster's own chance of this, stated with the estimate: 35%; middle value at least 2.5-fold (0.39 log units) from the limit.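

In this assay, methoxy in place of hydrogen on an aromatic carbon, meta to a large group and para to a methoxy group, brought an at least 4.0-fold higher number from compound 2 to compound 4 (0.60 log units; beyond the scatter). The same kind of change, at another place on the ring, cannot be compared in size on the core of compound 1, because both ends of the step from compound 1 to compound 3 sit at a limit: the limit of > 20000 nM in this assay, at which 3 of the 4 values shown sit. The result therefore shows a clear weakening on the core of compound 2 alone; it does not show that the change carries from one core to the other, and it gives only a lower bound for the size of the step.

The compounds shown leave open whether an amine or a carboxylic acid in place of the same hydrogen on the core of compound 2 would keep the number near that of compound 2. Also open, on these data alone, is whether a longer chain such as ethoxy would bring the core of compound 1 to a readable number in this assay.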